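The compounds below may be only part of what the source reports. "The series", "measured", "known", "first", "only" and "open" are said of these compounds alone.

Values so far in a functional assay on PC-3 cells (Homo sapiens) for inhibition, with a stated time of 48 h, tested at 50 uM; a higher number here means more inhibition of growth at the concentration tested, a lower number less inhibition of growth:
compound 1 `C=C[C@@](C)(/C=C/c1ccc(OC(=O)CCC)cc1)CCC=C(C)C` gives 38%
compound 2 `C=C[C@@](C)(/C=C/c1ccc(OC(=O)CCCC)cc1)CCC=C(C)C` gives 42%
compound 3 `C=C[C@@](C)(/C=C/c1ccc(OC(=O)CCCCCCCCCCCCCCC)cc1)CCC=C(C)C` gives 62%

Compound 2 at 42% cannot be separated from compound 1 and lies under compound 3, the highest of the three. The next compound to read is compound 4 `C=C[C@@](C)(/C=C/c1ccc(OC)cc1)CCC=C(C)C`. Its difference from compound 2 is methyl in place of butylcarbonyl on an oxygen on an aromatic ring and amounts to methyl in place of butylcarbonyl on an oxygen on an aromatic ring.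

For the measured compounds named here, three measured steps bear on this only indirectly, since all of them are changes in the saturated chain and the carbonyl stays in place. One stays within the scatter (a number 4 percentage points higher from compound 1 to compound 2 (within the scatter)). The two that reach the long chain are modest (a number 24 percentage points higher from compound 1 to compound 3 (beyond the scatter) and a number 20 percentage points higher from compound 2 to compound 3 (beyond the scatter)). Going by the values given here, no measured compound lacks the carbonyl, so the change itself has not been sampled, and the uncertainty is wide. The only clear rise in the set belongs to compound 3 (62%), and compound 4 carries no such chain, so no rise is expected. The expected move in this assay is small and downward (a number 7 percentage points lower from compound 2 to compound 4 (within the scatter)), most likely not beyond the scatter. For compound 4 the estimated value is 35% (expected range 17% to 53%).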

Compound 4, percent growth inhibition at one concentration: 44%
Beside the measured number, compound 4's estimate is 9 percentage points below it; the measured number falls inside the stated range.
By their numbers in this assay, from the lowest: compounds 1, 2 and 4 (each within the scatter of the next); then compound 3.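

In this assay, for the compounds shown here, methyl in place of butylcarbonyl on an oxygen on an aromatic ring takes the carbonyl out of the series for the first time, and the read-out shows no separation: a number 2 percentage points higher from compound 2 to compound 4 (within the scatter). The same holds for methyl in place of propylcarbonyl, with a number 6 percentage points higher from compound 1 to compound 4 (within the scatter), so at this oxygen the two short carbonyl-bearing groups and methoxy cannot be told apart, and among these three compounds the carbonyl is not required for this level of growth inhibition. Compound 3 gives 62% and compound 4 gives 44%, which still places the high value with the long chain of compound 3 and not with the carbonyl as such, and nothing at hand explains this.

Open, from the compounds shown here alone, is whether a long saturated chain fixed directly on that oxygen, with no carbonyl, would reach the value of compound 3, and at what chain length between butylcarbonyl and that of compound 3 the rise begins. Also open, going by these compounds, is what a free hydroxyl or an amine in place of the oxygen substituent would give.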